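Swapping tert-butyl for phenyl beside the hydroxyl

The source may hold more compounds than are shown below. What is called first, only, known or untested is meant among the compounds shown, and "the series" means these compounds.

Of the compounds shown here, three sharing one core have been measured in an ADME assay on liver for metabolic stability, with Liver microsome (Homo sapiens) as the target, read by LC-MS, using microsomes; a higher number here means faster removal of the compound, a lower number slower removal. Compound 1 `COC(C)(C)[C@@H](O)C(=O)N1N=CC[C@H]1C(=O)NCc1cc(Cl)ccc1-n1cnnn1` gives < 12 mL.min-1.g-1 in this assay, a limit of the assay rather than a number. Compound 2 `CC(C)(C)[C@@H](O)C(=O)N1OCC[C@H]1C(=O)NCc1cc(Cl)ccc1-n1cnnn1` likewise gives < 12 mL.min-1.g-1, again a limit. Compound 3 `Cc1cccc([C@@H](O)C(=O)N2N=CC[C@H]2C(=O)NCc2cc(Cl)ccc2-n2cnnn2)c1` gives < 12 mL.min-1.g-1, also a limit. Compound 2 therefore stands at the limit of this assay, where all three values shown sit (the limit of < 12 mL.min-1.g-1 in this assay, at which 3 of the 3 values shown sit).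

Compound 4 `O=C(NCc1cc(Cl)ccc1-n1cnnn1)[C@@H]1CCON1C(=O)[C@H](O)c1ccccc1` differs from compound 2 in one place: phenyl in place of tert-butyl on a saturated chain carbon bound to a carbonyl carbon and an oxygen on a saturated carbon.

Among the measured compounds shown here, only one measured step resembles this change, the one from compound 1 to compound 3 a step that the two limits leave unreadable from compound 1 to compound 3, where 3-methylphenyl replaces 1-methoxy-1-methylethyl on a saturated chain carbon bound to a carbonyl carbon and an oxygen on a saturated carbon. Both of its endpoints are limits, so its size cannot be read. The three limits together indicate that the shared core, with several different groups at this carbon, stays at the limit in this assay.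

Compound 4 is therefore expected to remain at the limit, with an estimated step from compound 2 of a step that the limit leaves unreadable from compound 2 to compound 4, meaning no change beyond the scatter. The estimate for compound 4 in this assay is 8 mL.min-1.g-1, with a range from 3 mL.min-1.g-1 to 25 mL.min-1.g-1.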

Compound 4, intrinsic clearance in microsomes: < 12 mL.min-1.g-1
Compound 4: a limit, no number (the forecaster's own chance of this, stated with the estimate: 70%); the middle value lies beyond the limit too.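

Compound 2 and compound 4 both give a limit rather than a number in this assay, so the size of the step from tert-butyl to phenyl cannot be read. All the compounds shown share this result: the limit of < 12 mL.min-1.g-1 in this assay, at which 4 of the 4 values shown sit.

The compounds shown leave open how fast each one is actually removed, and whether this swap changes that rate at all.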